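The compounds below may be only part of what the source reports. "The series", "measured", "known", "first", "only" and "open" are said of these compounds alone.

Of the compounds shown here, three that share one core have been measured in a functional assay on SW-620 cells (Homo sapiens) for cytotoxicity, read by MTT assay, with a stated time of 48 h; a higher number here means a weaker inhibitor, a lower number a stronger inhibitor. Compound 1 `CCCCCCCCCCCCCCNC(=O)[C@@H](NC(=O)c1ccco1)[C@@H](C)O` gives 200000 nM. Compound 2 `CCCCCCCCCCCCCCNC(=O)[C@@H](NC(=O)c1cc2ccccc2[nH]1)[C@@H](C)O` gives 15200 nM. Compound 3 `C/C=C/C=C/C(=O)N[C@H](C(=O)NCCCCCCCCCCCCCC)[C@@H](C)O` gives 200000 nM, which is level with compound 1 and, with it, the highest of the three numbers; its furthest neighbour is compound 2, with a 13-fold higher number from compound 2 to compound 3 (1.12 log units; beyond the scatter).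

Compound 4 `CCCCCCCCCCCCCCNC(=O)[C@@H](NS(=O)(=O)c1cccs1)[C@@H](C)O` has not yet been measured. It differs from compound 3 in one place: (thiophen-2-yl)sulfonyl in place of (penta-1,3-dien-1-yl)carbonyl on an amine nitrogen. The measured steps that bear on this position are no change at the digits printed from compound 1 to compound 3 (within the scatter) and a 13-fold higher number from compound 2 to compound 3 (1.12 log units; beyond the scatter). The first shows that swapping the penta-1,3-dien-1-yl group for a five-membered aromatic ring with one hetero atom did nothing beyond the scatter, while only the bicyclic indole in compound 2 moved the number. For the measured compounds named here, no measured step exchanges a carbonyl for a sulfonyl, so that part of the change is without precedent here. Since the entering group is again a five-membered aromatic ring with one hetero atom, the expectation for compound 4 is a step of a 1.3-fold lower number from compound 3 to compound 4 (0.12 log units; within the scatter), at most a modest lowering. Compound 4 is therefore estimated at 150000 nM, within a range from 30000 nM to 300000 nM.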

Compound 4, half-maximal inhibitory concentration: 18400 nM
Compound 4: middle estimate off by 8.2-fold (0.91 log units), on the high side; the whole stated range lies above it.
By their numbers in this assay, from the lowest: compounds 2 and 4 (each within the scatter of the next); then compounds 1 and 3 (each within the scatter of the next).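

The amine nitrogen of the shared core can reach a low number in this assay without the bicyclic 1H-indol-2-yl group: (thiophen-2-yl)sulfonyl in place of (penta-1,3-dien-1-yl)carbonyl gives a large drop (an 11-fold lower number from compound 3 to compound 4 (1.04 log units; beyond the scatter)), and the swap from (furan-2-yl)carbonyl gives a drop of the same size (an 11-fold lower number from compound 1 to compound 4 (1.04 log units; beyond the scatter)). Against the indole compound the change stays within the scatter (a 1.2-fold higher number from compound 2 to compound 4 (0.08 log units; within the scatter)), so a single five-membered aromatic ring reaches the level that, among the carbonyl compounds, only the 1H-indol-2-yl group reached. No measurement shown gives a reason for this shift.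

Compound 4 differs from compound 1 in both the linking group and the ring, so the part played by the sulfonyl and the part played by the thiophene cannot be separated; a (thiophen-2-yl)carbonyl or a (furan-2-yl)sulfonyl group would tell them apart. From the compounds shown here alone, whether the low number survives with a phenylsulfonyl or methylsulfonyl group on this nitrogen, or with a shorter chain elsewhere on the core, also remains open.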